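The compounds below may be only part of what the source reports. "The series", "measured", "known", "first", "only" and "open" are said of these compounds alone.

In an ADME assay on KB cells (Homo sapiens) for cytotoxicity, read by MTT assay, with a stated time of 72 h (on this read-out higher numbers stand for weaker inhibition and lower numbers for stronger inhibition), compound 1 `COc1ccc(C2=C(c3cc(OC)c(OC)c(OC)c3)C(=O)C(OC(C)=O)C2)cc1OC(C)C` gives > 100 ug/mL, which is a limit of the assay and not a number. Among the measured compounds shown here, compound 2 `COc1ccc(C2=C(c3cc(OC)c(OC)c(OC)c3)C(=O)C(OC(C)=O)C2)cc1` gives 72 ug/mL, the only actual number so far. Compound 3 `COc1ccc(C2=C(c3cc(OC)c(OC)c(OC)c3)C(=O)C(OC(C)=O)C2)cc1F` differs from compound 2 by fluoro in place of hydrogen on an aromatic carbon, with fluoro in place of hydrogen on an aromatic carbon, ortho to a methoxy group. For the measured compounds named here, the one measured step at that carbon, an at least 1.3-fold lower number from compound 1 to compound 2 (0.14 log units; that floor lies within the scatter), has a floor within the scatter, so it gives no reason to expect a clear shift. The expected step is a 1.0-fold lower number from compound 2 to compound 3 (0.01 log units; within the scatter), with no direction expected beyond the scatter. Compound 3 is estimated at 70 ug/mL, with an expected range of 35 ug/mL to 130 ug/mL.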

Compound 3, half-maximal inhibitory concentration: 33 ug/mL
Beside the measured number, compound 3's estimate is 2.1-fold (0.33 log units) above it; the whole stated range lies above it.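

At this aromatic carbon, ortho to a methoxy group, the read-out in this assay now shifts clearly: adding fluoro gives a 2.2-fold lower number from compound 2 to compound 3 (0.34 log units; beyond the scatter), the first step shown that lies beyond the scatter. Fluoro in place of isopropoxy gives an at least 3.0-fold lower number from compound 1 to compound 3 (0.48 log units; beyond the scatter). That size is only a floor, as compound 1 stands at a limit of the assay and not at a number: the limit of > 100 ug/mL in this assay, at which 1 of the 3 values shown sits.

On these data alone, whether this shift is particular to fluoro remains open, as a chloro, hydroxyl or amine group at the same carbon would show.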